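The source may hold more compounds than are shown below. What is called first, only, known or untested is meant among the compounds shown, and "the series" means these compounds.

Measured compounds:
- compound 1 `COc1ccccc1N1CCN(CCCNc2ncc(C#N)cc2C(=O)N(C)C)CC1`: 0.794 nM
- compound 2 `COc1ccccc1N1CCN(CCCSc2ccccc2C(=O)N(C)C)CC1`: 2 nM
- compound 3 `CN(C)C(=O)c1cccnc1NCCCN1CCN(c2ccccc2O)CC1`: 5.01 nM

In a functional assay for antagonist activity at Alpha-1A adrenergic receptor (Oryctolagus cuniculus) (on this read-out higher numbers stand for weaker binding and lower numbers for tighter binding), compound 3 gives 5.01 nM, the highest number of the three; the gaps to compound 2 and to compound 1 both lie beyond the scatter, so compound 3 is the weakest binder shown. Going by the values given here, compound 1 and compound 2 carry a methoxy group where compound 3 carries a hydroxy group, and both give lower numbers; no single-point step between measured compounds is available, so nothing about the size of such a change is settled here.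

Compound 4 `CN(C)C(=O)c1cccnc1NCCCN1CCN(c2ccccc2-c2ccccc2)CC1` is not yet measured. It differs from compound 3 by phenyl in place of hydroxy on an aromatic carbon. A step of modest size toward tighter binding is expected in this assay, plausibly not far beyond the scatter, since the move from compound 3 is a 1.6-fold lower number from compound 3 to compound 4 (0.19 log units; within the scatter) as estimated. Compound 4 is expected to give about 3.2 nM in this assay, within a range of 0.8 nM to 13 nM.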

Compound 4, dissociation constant: 1.26 nM
Estimate against measurement, compound 4: 2.5-fold (0.40 log units) above; measured number inside the range.
By their numbers in this assay, from the lowest: compounds 1, 4 and 2 (each within the scatter of the next, the first and the last beyond it); then compound 3.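

Phenyl in place of hydroxy on an aromatic carbon, ortho to a large group, gives a 4.0-fold lower number from compound 3 to compound 4 (0.60 log units; beyond the scatter) in this assay as the first single-place step in the series. This position therefore accepts a six-membered aromatic ring of carbon only, without the hydrogen-bond donor and acceptor of hydroxy, and binding is tighter. No measurement shown bears on the reason for this step.

As far as these compounds go, whether the lower number follows the added ring or the lost hydroxy stays open. Also open, from the compounds shown here alone, is how an amine or a benzyl group would read at this position on the core of compound 4.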